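Series notes: shift from compound 3 to compound 4

The compounds below may be only part of what the source reports. "The series", "measured", "known", "first", "only" and "open" are said of these compounds alone.

Compound 3 `O=c1c2ccccc2[se]n1-c1nnc(-c2ccccc2Cl)s1` holds the lowest number among the three measured: in a functional assay on MCF7 cells (Homo sapiens) for antiproliferative activity, read by CCK-8 assay, with a stated time of 48 h (a higher number here means a weaker inhibitor, a lower number a stronger inhibitor), compound 3 gives 4430 nM. Compound 1 `O=c1c2ccccc2[se]n1-c1nnc(-c2ccc(Cl)cc2)s1` gives 19500 nM and compound 2 `COc1ccc(-c2nnc(-n3[se]c4ccccc4c3=O)s2)cc1` gives 10000 nM. The structural change to compound 4 `Cc1ccc(-c2nnc(-n3[se]c4ccccc4c3=O)s2)cc1` is 4-methylphenyl in place of 2-chlorophenyl on an aromatic carbon. Among the measured compounds shown here, two measured steps bear on it. The step of a 4.4-fold lower number from compound 1 to compound 3 (0.64 log units; beyond the scatter) shows that moving from 4-chlorophenyl to 2-chlorophenyl brought a modest gain, so the return to a 4-substituted phenyl in compound 4 is expected to give that gain back. The step of a 2.0-fold lower number from compound 1 to compound 2 (0.29 log units; within the scatter) shows that exchanging one 4-substituent for another changed little. Compound 4 therefore is expected to sit in the range of compound 1 and compound 2 rather than compound 3, and the step of a 2.0-fold higher number from compound 3 to compound 4 (0.31 log units; beyond the scatter) is expected to run toward a higher number. The estimate for compound 4 in this assay is 9000 nM, with a range from 3500 nM to 25000 nM.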

Compound 4, half-maximal inhibitory concentration: 18700 nM
Estimate against measurement, compound 4: 2.1-fold (0.32 log units) below; low and high end bracket the measured number.
By their numbers in this assay, from the lowest: compound 3; then compounds 2, 4 and 1 (each within the scatter of the next).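

In this assay the 4-methylphenyl of compound 4 does not keep what the 2-chlorophenyl of compound 3 gave, and the change costs a modest amount: a 4.2-fold higher number from compound 3 to compound 4 (0.63 log units; beyond the scatter). A third 4-substituent now joins the other two without separating from them, with a 1.0-fold lower number from compound 1 to compound 4 (0.02 log units; within the scatter) and a 1.9-fold higher number from compound 2 to compound 4 (0.27 log units; within the scatter), so chloro, methoxy and methyl on the phenyl ring are not told apart here, and among these four compounds only compound 3 stands apart. No measurement at hand gives a reason for this gap.

Whether the lower number of compound 3 goes with chlorine itself or with where it sits on the phenyl ring stays open, as compound 3 is the only compound shown with 2-chlorophenyl. Also open, going by these compounds, is how an amine or a carboxylic acid on that ring, or a longer chain in place of the methyl, would read.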